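This account rests on a few compounds, and the source may have more. Where it says the series, first, only, none or still open, it means among the compounds named here.

Measured so far:
compound 1 `O=C(Nc1sc2c(c1C(=O)NNc1ccccc1)CCCCC2)NS(=O)(=O)c1ccccc1` — in a functional assay on cells (Cancer cell lines, Homo sapiens) for inhibition, with a stated time of 48 h (a lower number here means a stronger inhibitor of growth, a higher number a weaker inhibitor of growth), compound 1 gives 18500 nM
compound 2 `O=C(Nc1sc2c(c1C(=O)NNc1ccc(Br)cc1)CCCCC2)NS(=O)(=O)c1ccccc1` — in this assay compound 2 gives 5300 nM

Compound 2 stands with the lower of the two numbers. Among the compounds with values here, the only measured step is a 3.5-fold lower number from compound 1 to compound 2 (0.54 log units; beyond the scatter). Compound 3 `O=C(Nc1sc2c(c1C(=O)N1CCN(c3ccccc3)CC1)CCCCC2)NS(=O)(=O)c1ccccc1` carries 4-phenylpiperazin-1-yl in place of ((4-bromophenyl)amino)amino on a carbonyl carbon. Within the data shown here, no measured step touches the carbonyl carbon, so the bromo step gives no guidance here, and the direction of the change is open. For compound 3 the expected value is 8000 nM, with a range from 2000 nM to 30000 nM. That estimate means an expected step of a 1.5-fold higher number from compound 2 to compound 3 (0.18 log units; within the scatter), not clearly beyond the scatter in either direction.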

Compound 3, concentration for 50% growth inhibition: 58200 nM
Estimate against measurement, compound 3: 7.3-fold (0.86 log units) below; measured number outside the range, above it.
By their numbers in this assay, from the lowest: compound 2; then compound 1; then compound 3.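

In this assay the group on the carbonyl carbon proves a sensitive place: 4-phenylpiperazin-1-yl costs growth inhibition against ((4-bromophenyl)amino)amino (an 11-fold higher number from compound 2 to compound 3 (1.04 log units; beyond the scatter)) and against anilinoamino (a 3.1-fold higher number from compound 1 to compound 3 (0.50 log units; beyond the scatter)). Compound 3 is thus the weakest of the three, and both steps lie beyond the scatter. Nothing available accounts for this loss.

Open, going by these compounds, is whether bromo on the phenyl ring of compound 3 would lower the number. Also open, on these data alone, is whether a morpholine or a benzylamine on the carbonyl carbon would behave like 4-phenylpiperazin-1-yl.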